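A few compounds are considered here, and "the series" means these few. Any claim that something is new, unique, unknown or untested is made for them only; others in the source may bear on it.

Working notes on the hydroxycoumarin series.

Two members have numbers in an assay on CHO cells for displacement of a labelled ligand from adenosine receptor A3 (Homo sapiens), read by radioligand binding (a higher number here means a weaker inhibitor, a lower number a stronger inhibitor), so far. Compound 1 `O=c1oc2c(O)c(O)ccc2cc1-c1ccc(O)cc1` carries two hydroxy groups on the fused core and one on the pendant ring; in this assay compound 1 gives 9160 nM. Compound 2 `O=c1oc2c(O)cccc2cc1-c1ccc(O)c(O)c1` carries one hydroxy group on the fused core and two on the pendant ring; in this assay compound 2 gives 23600 nM. Compound 2 stands at the highest of the two numbers, with compound 1 the nearest at a lower number, and that gap lies beyond the scatter. Going by the values given here, the two compounds differ in more than one place, so no single step connects them.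

Compound 3 `O=c1oc2c(O)c(O)ccc2cc1-c1ccc(O)c(O)c1` is made from compound 2 by hydroxy in place of hydrogen on an aromatic carbon, a hydroxy in place of hydrogen on an aromatic carbon of the fused core. Only the two numbers above bear on the expectation. Since compound 1, the member with two hydroxy groups on the core, gives 9160 nM, a downward step of modest size is expected from compound 2 to compound 3, a 2.4-fold lower number from compound 2 to compound 3 (0.37 log units; beyond the scatter), and the direction is held with limited confidence. Compound 3 is estimated in this assay at 10000 nM, within a range from 3500 nM to 30000 nM.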

Compound 3, inhibition constant: 8500 nM
Beside the measured number, compound 3's estimate is 1.2-fold (0.07 log units) above it, within the range that was stated.
By their numbers in this assay, from the lowest: compounds 3 and 1 (each within the scatter of the next); then compound 2.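

In this assay, going by these compounds alone, hydroxy in place of hydrogen on an aromatic carbon of the fused core gives a 2.8-fold lower number from compound 2 to compound 3 (0.44 log units; beyond the scatter), the first single-place reading of this position, which is ortho to a hydroxy group, meta to a fused ring and para to a fused ring. The same kind of change on the pendant ring gives a 1.1-fold lower number from compound 1 to compound 3 (0.03 log units; within the scatter), so among these three compounds the added hydroxy on the core produces a step beyond the scatter, while the added hydroxy on the pendant ring does not. Nothing at hand offers an explanation for either step.

Going by these compounds, whether the step at this core position is specific to hydroxy remains open, since a methoxy group, an amine or a carboxylic acid at the same carbon could give a different number. Also open, on these data alone, is whether the step depends on the hydroxy group to which this position is ortho, a question that would need a pair lacking that group.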